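A few compounds are considered here, and "the series" means these few. Any claim that something is new, unique, unknown or untested is made for them only; others in the source may bear on it.

Compound 3 `CN(C)c1ccc(C2CC(c3ccc(-n4cncn4)cc3)=NN2C(=O)c2ccc(F)cc2)cc1` in a functional assay on MDA-MB-231 cells (Homo sapiens) for inhibition, read by sulforhodamine B assay, tested at 10 uM (a higher number here means more inhibition at the concentration tested (going by the name of the read-out), a lower number less inhibition), gives 12.5%, the value from which both other measured compounds differ only within the scatter: compound 1 `CN(C)c1ccc(C2CC(c3ccc(-n4cncn4)cc3)=NN2)cc1` gives 7%, and compound 2 `CN(C)c1ccc(C2CC(c3ccc(-n4cncn4)cc3)=NN2C(=O)CCCl)cc1` gives 3.7%. Compound 4 `CN(C)c1ccc(C2CC(c3ccc(-n4cncn4)cc3)=NN2C(=O)c2cc(Cl)cc(Cl)c2)cc1` differs from compound 3 by 3,5-dichlorophenyl in place of 4-fluorophenyl on a carbonyl carbon. The step that bears most directly on this change is the one on the same carbonyl carbon, a number 8.8 percentage points higher from compound 2 to compound 3 (within the scatter), which stays within the scatter, as do a number 3.3 percentage points lower from compound 1 to compound 2 (within the scatter) and a number 5.5 percentage points higher from compound 1 to compound 3 (within the scatter). No step beyond the scatter is therefore expected in this assay for compound 4. Compound 4 is estimated at 12%, with a range from 2% to 26%. The expected step is a number 0.5 percentage points lower from compound 3 to compound 4 (within the scatter).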

Compound 4, a percentage reported as inhibition, at one concentration (the size of the read-out at that concentration, not a potency): 9.4%
The estimate for compound 4 lay 2.6 percentage points above the measured number; the measured number falls inside the stated range.
By their numbers in this assay, from the lowest: compounds 2, 1, 4 and 3 (each within the scatter of the next).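

In this assay, a second substituted phenyl on this carbonyl carbon, 3,5-dichlorophenyl in place of 4-fluorophenyl, gives a number 3.1 percentage points lower from compound 3 to compound 4 (within the scatter) and so opens no gap between the two groups. The comparisons with 2-chloroethyl, a number 5.7 percentage points higher from compound 2 to compound 4 (within the scatter) and with hydrogen on the ring nitrogen, a number 2.4 percentage points higher from compound 1 to compound 4 (within the scatter) also stay within the scatter, so all four compounds remain indistinguishable here. Nothing measured here gives a reason for these steps. From the compounds shown here alone, whether an amine or a carboxylic acid on the phenyl ring, or a longer chain on the carbonyl carbon, would produce a step beyond the scatter remains open.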